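Swapping a nitrophenyl for a quinolinyl on the shared core

The source may report more compounds than this note shows. Statements on the series, on what has been measured and on what is new or still open speak of the compounds shown alone.

Measured so far in a functional assay on HepG2 cells (Homo sapiens) for antiproliferative activity, read by MTT assay; on this read-out higher numbers stand for weaker inhibition and lower numbers for stronger inhibition:
- compound 1 `O=C1N=C(N2CCC[C@H]2C(=O)Nc2ccc3ncnc(Nc4cccc(Cl)c4)c3c2)S/C1=C/c1cccnc1`: 8500 nM
- compound 2 `O=C1N=C(N2CCC[C@H]2C(=O)Nc2ccc3ncnc(Nc4cccc(Cl)c4)c3c2)S/C1=C/c1cccs1`: 4120 nM
- compound 3 `O=C1N=C(N2CCC[C@H]2C(=O)Nc2ccc3ncnc(Nc4cccc(Cl)c4)c3c2)S/C1=C/c1ccccc1[N+](=O)[O-]`: 32500 nM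

Compound 3 gives the highest number of the three, so it is the weakest here. Compound 4 `O=C1N=C(N2CCC[C@H]2C(=O)Nc2ccc3ncnc(Nc4cccc(Cl)c4)c3c2)S/C1=C/c1ccc2ccccc2n1` differs from it in one place: quinolin-2-yl in place of 2-nitrophenyl on a double-bonded chain carbon bound to a double-bonded ring carbon. For the measured compounds named here, the steps that bear on this swap are those onto the same carbon: a 3.8-fold higher number from compound 1 to compound 3 (0.58 log units; beyond the scatter) and a 7.9-fold higher number from compound 2 to compound 3 (0.90 log units; beyond the scatter), both weakening. Going by the values given here, a ring-bearing group with a ring nitrogen, like the one in compound 1, therefore points toward a lower number than compound 3. Compound 4 is expected to land near compound 1, with a 4.1-fold lower number from compound 3 to compound 4 (0.61 log units; beyond the scatter). The estimate for compound 4 is 8000 nM, ranging from 2500 nM to 25000 nM.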

Compound 4, half-maximal inhibitory concentration: 22900 nM
Beside the measured number, compound 4's estimate is 2.9-fold (0.46 log units) below it; the measured number falls inside the stated range.
By their numbers in this assay, from the lowest: compound 2; then compound 1; then compounds 4 and 3 (each within the scatter of the next).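

In this assay, the step to the two-ring quinolin-2-yl is a 1.4-fold lower number from compound 3 to compound 4 (0.15 log units; within the scatter), so this swap brings no real change from 2-nitrophenyl. A ring nitrogen alone therefore does not secure a lower number at this carbon: the steps of a 2.7-fold higher number from compound 1 to compound 4 (0.43 log units; beyond the scatter) and a 5.6-fold higher number from compound 2 to compound 4 (0.74 log units; beyond the scatter) separate quinolin-2-yl from the two single-ring groups, pyridin-3-yl and thiophen-2-yl. Nothing available explains these differences. Still open, on these data alone, is how a plain phenyl, or a phenyl carrying an amine or a carboxylic acid, would compare at this carbon.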